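The source may report more compounds than this note shows. Statements on the series, on what has been measured and on what is new or still open speak of the compounds shown alone.

- Compound 1 `O=C1CCCCC/C1=C\c1cccc(F)c1`: 482000 nM
- Compound 2 `O=C1CCCCC/C1=C\c1cccc(Cl)c1`: 88600 nM
- Compound 3 `Cc1cccc(/C=C2\CCCCCC2=O)c1`: 228000 nM

In a functional assay on MOLT-4 cells (Homo sapiens) for inhibition (a higher number here means a weaker inhibitor, a lower number a stronger inhibitor), compound 3 gives 228000 nM, the middle of these three numbers. Compound 4 `O=C1CCCCC/C1=C\c1cccc([N+](=O)[O-])c1` has nitro in place of methyl on an aromatic carbon. Among the measured compounds shown here, no nitro compound has been measured yet, so the best guide is what swaps at this same place have done so far. They gave a 5.4-fold lower number from compound 1 to compound 2 (0.74 log units; beyond the scatter), a 2.1-fold lower number from compound 1 to compound 3 (0.33 log units; beyond the scatter) and a 2.6-fold higher number from compound 2 to compound 3 (0.41 log units; beyond the scatter), all modest. A modest step is therefore expected, and these swaps give no firm direction. The estimated change is a 1.3-fold lower number from compound 3 to compound 4 (0.13 log units; within the scatter). For compound 4 the expected value is 170000 nM, with an estimated range of 50000 nM to 500000 nM.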

Compound 4, half-maximal inhibitory concentration: 39200 nM
Compound 4: middle estimate off by 4.3-fold (0.64 log units), on the high side, outside the stated range (below it).
By their numbers in this assay, from the lowest: compound 4; then compound 2; then compound 3; then compound 1.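

Nitro on this aromatic carbon gives the strongest inhibitor of the four in this assay, with a 5.8-fold lower number from compound 3 to compound 4 (0.76 log units; beyond the scatter) and a 2.3-fold lower number from compound 2 to compound 4 (0.35 log units; beyond the scatter) and a 12-fold lower number from compound 1 to compound 4 (1.09 log units; beyond the scatter). The last of these is the only step so far printed as large, so this position can shift the number further than the swaps among fluoro, chloro and methyl had shown. No measurement available here explains the gain. Still open, on these data alone, is whether an amine or a carboxylic acid on this same carbon would lower the number further or raise it.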